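Chloro to methyl swap across two cores of the series

This account rests on a few compounds, and the source may have more. Where it says the series, first, only, none or still open, it means among the compounds named here.

Compound 1 `CCc1nc2c(C)cc(C)nc2n1Cc1ccc(OC(C(=O)O)c2ccccc2)c(Cl)c1` and compound 2 `CCc1nc2c(C)cc(C)nc2n1Cc1ccc(OC(C(=O)O)c2ccccc2)c(C)c1` share one core and differ in a single place, (methyl in place of chloro on an aromatic carbon). In an assay on Midbrain with Type-2 angiotensin II receptor (Rattus norvegicus) as the target (on this read-out higher numbers stand for weaker inhibition and lower numbers for stronger inhibition), compound 1 gives 720 nM. In this assay compound 2 gives 940 nM. The step is a 1.3-fold higher number from compound 1 to compound 2 (0.12 log units; within the scatter), so the two values are not distinguished by this change.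

Compound 3 `CCCc1cc(Cn2c(CC)nc3c(C)cc(C)nc32)ccc1OC(C(=O)O)c1ccccc1Cl` carries a different core; the difference between the core of compound 3 and the core of compound 1 is not broken down here. For compound 3 this assay reports only a limit, > 1000 nM, which is the limit of > 1000 nM in this assay, at which 1 of the 3 values shown sits.

Compound 4 `CCCc1cc(Cn2c(CC)nc3c(C)cc(C)nc32)ccc1OC(C(=O)O)c1ccccc1C` is not yet measured. It differs from compound 3 by methyl in place of chloro on an aromatic carbon. This is the same kind of change as from compound 1 to compound 2, not the same: in compound 1 the place is ortho to a large group and meta to a large group, whereas in compound 3 it is ortho to a large group only.

The expectation for compound 4 rests on the step of a 1.3-fold higher number from compound 1 to compound 2 (0.12 log units; within the scatter), which is within the scatter, and on the limit recorded for compound 3. Compound 4 is therefore expected to sit near that limit, with an estimated step that the limit leaves unreadable from compound 3 to compound 4. The estimate for compound 4 is 1500 nM, with a range from 700 nM to 4000 nM; a limit rather than a number is the more likely outcome.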

Compound 4, half-maximal inhibitory concentration: 2400 nM
Compound 4: middle estimate off by 1.6-fold (0.20 log units), on the low side; low and high end bracket the measured number.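

No step can be read between compound 3 and compound 4 in this assay because the value for compound 3 is only a limit: the limit of > 1000 nM in this assay, at which 1 of the 4 values shown sits.

The compounds shown leave open whether 2-methylphenyl in place of 2-chlorophenyl changes the number at all on the core of compound 3, and whether that change would match the step on the core of compound 1.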